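The source may hold more compounds than are shown below. What is called first, only, known or untested is meant among the compounds shown, and "the series" means these compounds.

Measured so far:
compound 1 `ClCc1ccc(Cn2cnc3c(Cl)ncnc32)cc1` — 640 nM
compound 2 `ClCc1ccccc1Cn1cnc2c(Cl)nc(Cl)nc21` — 1770 nM

In a functional assay on SF-268 cells (Homo sapiens) for cytotoxicity, read by sulforhodamine B assay, with a stated time of 48 h (a lower number here means a stronger inhibitor of growth, a higher number a weaker inhibitor of growth), compound 2 gives the higher of the two numbers; the nearest is compound 1, whose value sits beyond the scatter below it. The next member is compound 3 `ClCc1ccccc1Cn1cnc2c(Cl)ncnc21`, reached from compound 2 by hydrogen in place of chloro on an aromatic carbon, which leaves compound 3 with the core of compound 1. For the measured compounds named here, no measured pair shows this step directly. A drop of modest size is expected from compound 2 to compound 3 a 2.0-fold lower number from compound 2 to compound 3 (0.29 log units; within the scatter), since compound 1, carrying the same core, gives 640 nM. Compound 3 is therefore estimated at 900 nM in this assay, within 300 nM to 2700 nM.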

Compound 3, concentration for 50% growth inhibition: 3230 nM
Estimate against measurement, compound 3: 3.6-fold (0.55 log units) below; the whole stated range lies below it.
By their numbers in this assay, from the lowest: compound 1; then compounds 2 and 3 (each within the scatter of the next).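

In this assay the chloro group on the aromatic carbon between two ring nitrogen atoms gives way to hydrogen with a 1.8-fold higher number from compound 2 to compound 3 (0.26 log units; within the scatter) and this single change leaves compound 2 and compound 3 indistinguishable. The shared core does not by itself fix the number: compound 1 gives 640 nM while compound 3 gives 3230 nM on the same core.

Only chloro and hydrogen are shown at this position, so an amine or a methoxy group there remains an open case. Nothing available explains the result.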